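A few compounds are considered here, and "the series" means these few. Any claim that something is new, unique, unknown or untested is made for them only; others in the source may bear on it.

In a functional assay on MIA PaCa-2 cells (Homo sapiens) for inhibition, read by MTT assay, with a stated time of 48 h, tested at 10 uM (a higher number here means more inhibition of growth at the concentration tested, a lower number less inhibition of growth), compound 1 `Cc1oc2c([C@H]3CCN(C)C[C@H]3O)c(O)cc(O)c2c(=O)c1C(O)c1ccccc1Br` gives 10% and compound 2 `COc1ccc(C(O)c2c(C)oc3c([C@H]4CCN(C)C[C@H]4O)c(O)cc(O)c3c2=O)cc1Br` gives 3%. Within the data shown here, the only measured step runs a number 7 percentage points lower from compound 1 to compound 2 (within the scatter), so compound 2 stands within the scatter of its single neighbour, and both compounds show little inhibition of growth. Compound 3 `Cc1oc2c([C@H]3CCN(C)C[C@H]3O)c(O)cc(O)c2c(=O)c1C(O)c1cc(F)cc(F)c1` keeps the shared core and carries 3,5-difluorophenyl in place of 3-bromo-4-methoxyphenyl, on the same saturated chain carbon: 3,5-difluorophenyl in place of 3-bromo-4-methoxyphenyl on a saturated chain carbon bound to an aromatic carbon and an oxygen on a saturated carbon. Among the measured compounds shown here, that same carbon was the site of the one measured swap, a number 7 percentage points lower from compound 1 to compound 2 (within the scatter), which replaced 2-bromophenyl and stayed inside the scatter. Neither measured compound carries fluorine, so this evidence is thin and the range must stay wide. In this assay, the expected change is a number 5 percentage points higher from compound 2 to compound 3 (within the scatter), with no move beyond the scatter anticipated in either direction. For compound 3 the estimated value is 8%, with an expected range of 0% to 22%.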

Compound 3, percent growth inhibition at one concentration: 6%
The estimate for compound 3 lay 2 percentage points above the measured number, and the stated range covers the measured number.
By their numbers in this assay, from the lowest: compounds 2, 3 and 1 (each within the scatter of the next).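

In this assay the swap to 3,5-difluorophenyl gives a number 3 percentage points higher from compound 2 to compound 3 (within the scatter) and a number 4 percentage points lower from compound 1 to compound 3 (within the scatter) at this saturated chain carbon. A phenyl ring with fluorine and no bromine therefore falls in the same narrow band as the two bromine-bearing rings, and all three compounds show little inhibition of growth at the concentration tested. No measured property of these groups bears on this result, so the data offer no explanation for how closely the numbers agree.

Every group shown at this carbon is a substituted phenyl ring. On these data alone, whether an unsubstituted phenyl, a longer alkyl chain or a ring-bound amine here would move the number beyond the scatter remains open, as does the effect of changes elsewhere on the shared core.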